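The source may report more compounds than this note shows. Statements on the series, on what has been measured and on what is new or still open speak of the compounds shown alone.

Compound 1 `COc1nc2ccc(Br)cc2cc1C(c1ccccc1)n1cc(-c2ccccc2)nn1` has the higher number of the two compounds measured in an ADME assay on HEK293 cells (Homo sapiens) for cytotoxicity, read by sulforhodamine B assay, with a stated time of 48 h, tested at 10 uM (a higher number here means more inhibition at the concentration tested (going by the name of the read-out), a lower number less inhibition), where compound 1 gives 8.25%. Compound 2 `CCCCCc1cn(C(c2ccccc2)c2cc3cc(Br)ccc3nc2OC)nn1` differs in one group, and in this assay compound 2 gives -2%, a drop of a number 10.3 percentage points lower from compound 1 to compound 2 (beyond the scatter). Compound 3 `COc1nc2ccc(Br)cc2cc1C(c1ccccc1)n1cc(CO)nn1` is not yet measured; its change from compound 1 is hydroxymethyl in place of phenyl on an aromatic carbon. Within the data shown here, the only step that bears on it is the one from compound 1 to compound 2, which removed the same phenyl and was modest, so a small lowering is expected: a number 5.3 percentage points lower from compound 1 to compound 3 (within the scatter). Compound 3 is therefore estimated at 3%, between -8% and 14%.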

Compound 3, a percentage reported as inhibition, at one concentration (the size of the read-out at that concentration, not a potency): 11.5%
Beside the measured number, compound 3's estimate is 8.5 percentage points below it; low and high end bracket the measured number.
By their numbers in this assay, from the lowest: compound 2; then compounds 1 and 3 (each within the scatter of the next).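

In this assay hydroxymethyl in place of phenyl on this aromatic carbon gives a number 3.3 percentage points higher from compound 1 to compound 3 (within the scatter) and so cannot be told apart from phenyl here. Hydroxymethyl does stand apart from the pentyl of compound 2, with a number 13.5 percentage points higher from compound 2 to compound 3 (beyond the scatter) and this shows that the two replacements of phenyl do not behave alike at this position. Nothing measured here explains that difference. Going by these compounds, whether an amine, a carboxylic acid or a longer chain ending in hydroxy at this carbon would stay level with compound 1 or fall towards compound 2 remains open.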